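Series notes: terminal aryl swap toward a trifluoromethoxy variant

This account rests on a few compounds, and the source may have more. Where it says the series, first, only, none or still open, it means among the compounds named here.

Measured compounds in a functional assay on Jurkat cells (Homo sapiens); on this read-out lower numbers stand for stronger inhibition and higher numbers for weaker inhibition:
compound 1 `CC(C)[C@H](NC(=O)COc1cccc2ccccc12)C(=O)N[C@@H](CC(=O)O)C(=O)COc1ccc(-c2ccccc2)cc1` gives 87900 nM.
compound 2 `CC(C)[C@H](NC(=O)COc1cccc2ccccc12)C(=O)N[C@@H](CC(=O)O)C(=O)COc1ccccc1C(F)(F)F` gives only a limit of the assay, > 100000 nM.
compound 3 `CC(C)[C@H](NC(=O)COc1cccc2ccccc12)C(=O)N[C@@H](CC(=O)O)C(=O)COc1cc(C(F)(F)F)cc(C(F)(F)F)c1` likewise gives only a limit of the assay, > 100000 nM.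

Compound 2 stands at the limit of this assay, where two of the three values sit (the limit of > 100000 nM in this assay, at which 2 of the 3 values shown sit); no number is known for it. For the measured compounds named here, the one measured step that reaches compound 2 is an at least 1.1-fold higher number from compound 1 to compound 2 (0.05 log units; that floor lies within the scatter), and its floor lies within the scatter, so it tells little beyond the fact that both ends are weak.

Compound 4 `CC(C)[C@H](NC(=O)COc1cccc2ccccc12)C(=O)N[C@@H](CC(=O)O)C(=O)COc1ccc(OC(F)(F)F)cc1` is not yet measured. It differs from compound 2 by 4-(trifluoromethoxy)phenyl in place of 2-(trifluoromethyl)phenyl on an oxygen on a saturated carbon. Going by the values given here, no measured step involves a trifluoromethoxy group, so nothing in the measured steps speaks for a change in either direction beyond the scatter; compound 3, with two trifluoromethyl groups, also sits at the limit. The expected step is therefore a number no higher from compound 2 to compound 4 (the limit leaves the size open), with the estimate for compound 4 at 100000 nM between 40000 nM and 250000 nM, most likely again reported as a limit.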

Compound 4, half-maximal inhibitory concentration: 29100 nM
Beside the measured number, compound 4's estimate is 3.4-fold (0.54 log units) above it, and the stated range ends above it.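

In this assay, the group on this oxygen on a saturated carbon can move the number beyond the scatter, which the step from compound 1 to compound 2 could not show. Swapping in 4-(trifluoromethoxy)phenyl for 2-(trifluoromethyl)phenyl gives an at least 3.4-fold lower number from compound 2 to compound 4 (0.53 log units; beyond the scatter), while trifluoromethoxy in place of phenyl on an aromatic carbon gives a 3.0-fold lower number from compound 1 to compound 4 (0.48 log units; beyond the scatter). The first of these steps is only a floor, and its full size stays unknown because one end of it is a limit: the limit of > 100000 nM in this assay, at which 2 of the 4 values shown sit.

The compounds shown do not separate the effect of the group's identity from that of its place on the ring, since both differ between the two ends of the first step. Also open, going by these compounds, is how a nitrile or an amine would read in place of trifluoromethoxy on that aromatic carbon.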